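The source may hold more compounds than are shown below. What is called first, only, known or untested is meant among the compounds shown, and "the series" means these compounds.

- Compound 1 `Nc1ccc(-c2csc(-c3cccnc3)n2)cc1` gives 3000 nM
- Compound 2 `O=C1CCc2cc(-c3csc(-c4cccnc4)n3)ccc2N1` gives 1000 nM

In a functional assay for inhibition, with Homo sapiens as the target (a higher number here means a weaker inhibitor, a lower number a stronger inhibitor), compound 2 has the lower of the two numbers (1000 nM), and the gap up to compound 1 lies beyond the usual scatter. Compound 3 `O=C1CCc2cc(-c3csc(-c4ccccc4)n3)ccc2N1` has phenyl in place of pyridin-3-yl on an aromatic carbon. Within the data shown here, no measured pair shows this swap, so the expectation is tentative: a modest rise in the number, about the size of the scatter. The estimated change is a 2.0-fold higher number from compound 2 to compound 3 (0.30 log units; within the scatter) in this comparison. Compound 3 is expected near 2000 nM in this assay, with an estimated range from 500 nM to 10000 nM as the likely span.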

Compound 3, half-maximal inhibitory concentration: > 10000 nM
Compound 3: a limit, no number; the forecaster's own chance of this, stated with the estimate: 15%; middle value at least 5.0-fold (0.69 log units) away from the limit.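

In this assay, phenyl in place of pyridin-3-yl gives an at least 10-fold higher number from compound 2 to compound 3 (1.00 log units; beyond the scatter). Among these compounds, this is the first view of this position, and it shows that losing only the ring nitrogen, with its one hydrogen-bond acceptor, is enough to move the number well beyond the scatter. The reading for compound 3 is a limit and not a number: the limit of > 10000 nM in this assay, at which 1 of the 3 values shown sits.

From the compounds shown here alone, how far compound 3 lies past that limit stays open. So does whether pyrimidinyl, with a second ring nitrogen, would lower the number below that of compound 2.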